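Aryl swap on the shared core: compound 2 to compound 3

The source may hold more compounds than are shown below. What is called first, only, known or untested is meant among the compounds shown, and "the series" means these compounds.

- compound 1 `COc1ccc(S(=O)(=O)N2CCc3cccc(-c4ccc(F)cc4)c32)cc1` gives 86 nM
- compound 2 `COc1ccc(S(=O)(=O)N2CCc3cccc(-c4cccnc4)c32)cc1` gives 95.9 nM

In a functional assay on KB cells (Homo sapiens) for inhibition, with a stated time of 72 h (a lower number here means a stronger inhibitor, a higher number a weaker inhibitor), compound 2 stands at 95.9 nM and lies within the scatter of compound 1. The change to compound 3 `COc1ccc(S(=O)(=O)N2CCc3cccc(-c4ccc(O)cc4)c32)cc1` is 4-hydroxyphenyl in place of pyridin-3-yl on an aromatic carbon at the place already varied once. For the measured compounds named here, the only measured step there is a 1.1-fold higher number from compound 1 to compound 2 (0.05 log units; within the scatter) and it stays within the scatter. Going by the values given here, no 4-hydroxyphenyl compound has been measured, so the expectation in this assay is no step beyond the scatter, in either direction. The expected change is a 1.0-fold higher number from compound 2 to compound 3 (0.02 log units; within the scatter) by this estimate. Compound 3 is estimated at 100 nM with an expected range of 40 nM to 250 nM for the measurement.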

Compound 3, half-maximal inhibitory concentration: 129 nM
Estimate against measurement, compound 3: 1.3-fold (0.11 log units) below; low and high end bracket the measured number.
By their numbers in this assay, from the lowest: compounds 1, 2 and 3 (each within the scatter of the next).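

In this assay, a third aryl group at this aromatic carbon of the shared core gives a step of a 1.3-fold higher number from compound 2 to compound 3 (0.13 log units; within the scatter) that stays within the scatter. Hydroxy in place of fluoro on the phenyl ring, with a step of a 1.5-fold higher number from compound 1 to compound 3 (0.18 log units; within the scatter), also stays within the scatter, so 4-hydroxyphenyl, the only one of the three groups with a hydrogen-bond donor, does not separate from the other two. No measured evidence bears on why these numbers stand as they do.

Still open, from the compounds shown here alone, is whether a non-aryl group at this carbon, such as an amine, a carboxylic acid or a longer alkyl chain, would give a step beyond the scatter.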